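Swapping a carboxy for a protected amine on a spiro amide

The compounds below may be only part of what the source reports. "The series", "measured", "known", "first", "only" and "open" are said of these compounds alone.

Measured so far:
Compound 1 `CC(C)(C)OC(=O)NCCCCNC(=O)CN1CN(c2ccccc2)C2(CCN(C(=O)c3ccc(C(C)(C)C)cc3)CC2)C1=O` – "not determined" (no result reported) in an assay on HEK293 cells for displacement of a labelled ligand from NPC1-like intracellular cholesterol transporter 1 (Homo sapiens); on this read-out lower numbers stand for stronger inhibition and higher numbers for weaker inhibition.
Compound 2 `CC(C)(C)c1ccc(C(=O)N2CCC3(CC2)C(=O)N(CC(=O)NCCC(=O)O)CN3c2ccccc2)cc1` – 11400 nM.

Compound 2 carries the only number shown, and it is a weak one: in this assay compound 2 gives 11400 nM. Compound 1 shares the core but has no reported value, so nothing can be said about how it compares.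

Compound 3 `CC(C)(C)OC(=O)NCCCNC(=O)CN1CN(c2ccccc2)C2(CCN(C(=O)c3ccc(C(C)(C)C)cc3)CC2)C1=O` differs from compound 2 in one place: ((tert-butoxycarbonyl)amino)methyl in place of carboxy on a saturated chain carbon, two bonds along the chain from an amide-type nitrogen. For the measured compounds named here, no pair of measured compounds shows what this kind of exchange does here, so the direction of the change cannot be read from the data. The expectation is a small step, a 1.4-fold lower number from compound 2 to compound 3 (0.15 log units; within the scatter), that stays close to the usual scatter rather than clearly beyond it. Compound 3 is therefore estimated at 8000 nM, with a likely range from 2000 nM to 30000 nM.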

Compound 3, half-maximal inhibitory concentration: 4500 nM
Beside the measured number, compound 3's estimate is 1.8-fold (0.25 log units) above it, and the stated range covers the measured number.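

In this assay, for the compounds shown here, the first measured change at this place, on a saturated chain carbon, two bonds along the chain from an amide-type nitrogen, gives a 2.5-fold lower number from compound 2 to compound 3 (0.40 log units; beyond the scatter). The carboxy group is therefore not needed for the activity seen so far: the larger ((tert-butoxycarbonyl)amino)methyl group is accepted in its place, and the number even improves modestly, though compound 3 at 4500 nM is still a weak inhibitor. Nothing measured here gives a reason for this step.

The exchange alters both the end group and the chain length, so the compounds shown leave open which of the two matters. A free amine on the same propyl chain, or a carboxylic acid on a longer chain, would separate these effects.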